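Taking one methoxy from the trimethoxyphenyl group

The compounds below may be only part of what the source reports. "The series", "measured", "known", "first", "only" and "open" are said of these compounds alone.

In a functional assay on SMMC-7721 cells (Homo sapiens) for cytotoxicity, read by MTT assay, with a stated time of 24 h (a higher number here means a weaker inhibitor, a lower number a stronger inhibitor), compound 1 (`O=C1/C(=C/c2ccccc2F)CN(S(=O)(=O)c2ccc(F)cc2)C/C1=C\c1ccccc1F`) gives 8370 nM and compound 2 (`COc1cc(/C=C2\CN(S(=O)(=O)c3ccc(F)cc3)C/C(=C\c3ccccc3F)C2=O)cc(OC)c1OC`) gives 6340 nM. Going by the values given here, the two numbers lie within the scatter of each other, so compound 2 cannot be ranked against its only neighbour.

Compound 3 (`COc1cc(/C=C2\CN(S(=O)(=O)c3ccc(F)cc3)C/C(=C\c3ccccc3F)C2=O)cc(OC)c1`) differs from compound 2 in one place: hydrogen in place of methoxy on an aromatic carbon. This is hydrogen in place of methoxy on an aromatic carbon, which turns 3,4,5-trimethoxyphenyl into 3,5-dimethoxyphenyl.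

Among the compounds with values here, one measured step bears on this group: a 1.3-fold lower number from compound 1 to compound 2 (0.12 log units; within the scatter), which brought in the 3,4,5-trimethoxyphenyl group in place of 2-fluorophenyl. That exchange of the whole group stayed within the scatter, so the loss of one methoxy is expected to give no step beyond the scatter in this assay. The expected step is a 1.1-fold higher number from compound 2 to compound 3 (0.03 log units; within the scatter). For compound 3 the estimate is 6800 nM, with an expected range from 3200 nM to 14000 nM.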

Compound 3, half-maximal inhibitory concentration: 6890 nM
Compound 3: the middle estimate sits 1.0-fold (0.01 log units) below what was measured; the range from low to high includes it.
By their numbers in this assay, from the lowest: compounds 2, 3 and 1 (each within the scatter of the next).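

In this assay, replacing the methoxy on the aromatic carbon ortho to two methoxy groups and para to a large group gives a 1.1-fold higher number from compound 2 to compound 3 (0.04 log units; within the scatter), so this single position is now tested apart from the exchange of the whole group, and the change cannot be read as a difference. The 3,5-dimethoxyphenyl group likewise cannot be told apart from 2-fluorophenyl, with a 1.2-fold lower number from compound 1 to compound 3 (0.08 log units; within the scatter), so neither the trimethoxyphenyl nor the dimethoxyphenyl compound separates from compound 1. Nothing available gives a reason for this result.

On these data alone, it remains open whether an amine, a carboxylic acid or a longer alkoxy chain on that aromatic carbon would give a step beyond the scatter. Also open, as far as these compounds go, is whether changing the 2-fluorophenyl group that all three compounds share would do so.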